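The compounds below may be only part of what the source reports. "The series", "measured", "known", "first", "only" and "open" are said of these compounds alone.

Compound 1 `O=S1(=O)N=C(OCc2ccccc2)c2ccccc2N1Cc1ccccc1` reaches only the limit of a functional assay on HEL cells (Homo sapiens) for inhibition (a higher number here means that more compound is tolerated, a lower number that less compound is tolerated), reported as > 200000 nM.
Compound 2 `O=C1c2ccccc2N(Cc2ccccc2)S(=O)(=O)N1Cc1ccc(Cl)cc1` gives 121000 nM in this assay.
Compound 3 `O=C1c2ccccc2N(Cc2ccc(Cl)cc2)S(=O)(=O)N1Cc1ccc(Cl)cc1` also stops at a limit, > 200000 nM.

Compound 2 is the only one of these three with an actual number in this assay; the other two values are limits, so it stands alone rather than high or low. Going by the values given here, the one measured step that comes near it, an at least 1.6-fold higher number from compound 2 to compound 3 (0.21 log units; that floor lies within the scatter), adds a second chloro to the shared core and ends at a limit, so it says only that the tolerated concentration did not fall.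

Compound 4 `O=C1c2ccccc2N(Cc2ccccc2)S(=O)(=O)N1Cc1ccccc1Cl` differs from compound 2 by 2-chlorophenyl in place of 4-chlorophenyl on a saturated chain carbon bound to an amide-type nitrogen in a ring. Among the compounds with values here, none of the measured steps moves a chloro from one position on the phenyl to another, so there is no direct precedent here. The small step seen in an at least 1.6-fold higher number from compound 2 to compound 3 (0.21 log units; that floor lies within the scatter) suggests that a chloro on this benzyl group does not cut tolerance, and a positional shift of the same group is taken to be no different beyond the scatter. The estimated step of a 1.0-fold lower number from compound 2 to compound 4 (0.00 log units; within the scatter) is therefore expected to be flat. Compound 4 is expected to give about 120000 nM, between 50000 nM and 250000 nM.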

Compound 4, half-maximal cytotoxic concentration: > 200000 nM
Compound 4: no number, only a limit; the forecaster's own chance of this, stated with the estimate: 35%; at least 1.6-fold (0.22 log units) between middle value and limit.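

Moving the chloro within this group, from 4-chlorobenzyl to 2-chlorobenzyl on a saturated chain carbon bound to an amide-type nitrogen in a ring, gives an at least 1.6-fold higher number from compound 2 to compound 4 (0.21 log units; that floor lies within the scatter). Going by these compounds alone, this is the first look at where the chloro sits rather than whether a second one is present, and in this assay the move from the 4-chlorophenyl to the 2-chlorophenyl arrangement, with the same atoms joined differently, did not lower the tolerated concentration. On these data alone, its true size stays unknown, since the step is only a floor that lies within the scatter, and compound 4 now joins the compounds that give no actual number: the limit of > 200000 nM in this assay, at which 3 of the 4 values shown sit.

With compound 2 as the only compound here that gives an actual number, the compounds shown leave open whether the 2-chlorobenzyl group differs at all from the 4-chlorobenzyl group in this assay. As far as these compounds go, they also carry only hydrogen or chloro on these phenyl rings, so it remains open whether an amine or a carboxylic acid at the same place would give a value clearly different from that of compound 2.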